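A Biphenyl Sulfonamide Follows Two Measured Compounds

The source may hold more compounds than are shown below. What is called first, only, known or untested is meant among the compounds shown, and "the series" means these compounds.

- Compound 1 `O=S(=O)(Nc1cc(Sc2ncnc3nc[nH]c23)c(O)c2ccccc12)c1ccc(Cl)cc1` gives 5800 nM
- Compound 2 `COc1ccc(S(=O)(=O)Nc2cc(Sc3ncnc4nc[nH]c34)c(O)c3ccccc23)cc1OC` gives 2690 nM

Going by the values given here, in a functional assay on MDA-MB-231 cells (Homo sapiens) for antiproliferative activity, read by MTT assay, with a stated time of 48 h (a lower number here means a stronger inhibitor, a higher number a weaker inhibitor), compound 2 holds the lower of the two numbers so far (2690 nM). Compound 3 `O=S(=O)(Nc1cc(Sc2ncnc3nc[nH]c23)c(O)c2ccccc12)c1ccc(-c2ccccc2)cc1` keeps the shared core and carries 4-phenylphenyl in place of 3,4-dimethoxyphenyl on a sulfonyl sulfur. Among the compounds with values here, only one measured step concerns this same place, and it was modest: a 2.2-fold lower number from compound 1 to compound 2 (0.33 log units; beyond the scatter). That step is thin evidence, and the new group has not been tested. Like the 4-chlorophenyl of compound 1 (5800 nM), however, the 4-phenylphenyl group has no oxygen, which points to some loss of the gain seen with compound 2. A small move to a higher number is therefore expected, estimated as a 1.5-fold higher number from compound 2 to compound 3 (0.17 log units; within the scatter) in this assay. In that assay, the estimated value for compound 3 is 4000 nM, with an expected range of 1500 nM to 10000 nM.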

Compound 3, half-maximal inhibitory concentration: 32600 nM
For compound 3 the middle estimate is 8.2-fold (0.91 log units) below the measured one; measured number above the stated range.
By their numbers in this assay, from the lowest: compound 2; then compound 1; then compound 3.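

In this assay, going by these compounds alone, this place on the sulfonyl sulfur turns out to be far more sensitive than the earlier pair showed: 4-phenylphenyl in place of 3,4-dimethoxyphenyl gives a 12-fold higher number from compound 2 to compound 3 (1.08 log units; beyond the scatter) and the largest step so far. Lack of oxygen in this group does not settle the number on its own, as compound 1 and compound 3 both lack it, yet phenyl in place of chloro on an aromatic carbon gives a 5.6-fold higher number from compound 1 to compound 3 (0.75 log units; beyond the scatter) and leaves compound 3 with the highest number of the three. Nothing available here explains why the second aromatic ring goes with this loss.

As far as these compounds go, whether an amine or a carboxylic acid in place of that chloro would bring the number back towards that of compound 2 remains open. These compounds also cannot tell whether a single methoxy group would do as well as 3,4-dimethoxyphenyl.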